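The source may hold more compounds than are shown below. What is called first, only, known or untested is meant among the compounds shown, and "the series" means these compounds.

Measured so far in a functional assay on cells for antagonist activity at C-X-C chemokine receptor type 4 (Homo sapiens), read by fluorescence and calcium flux, with stated times of 25 min and 90 s; on this read-out higher numbers stand for weaker inhibition and lower numbers for stronger inhibition:
compound 1 `c1ccc2c(c1)CN[C@@H](CN(CCCCNCC1CCSCC1)[C@H]1CCCc3cccnc31)C2` — 69.6 nM
compound 2 `O=S1(=O)CCC(CNCCCCN(C[C@H]2Cc3ccccc3CN2)[C@H]2CCCc3cccnc32)CC1` — 17 nM

Compound 2 gives the lower of the two numbers; compound 1 gives the higher, the gap being a 4.1-fold lower number from compound 1 to compound 2 (0.61 log units; beyond the scatter). Within the data shown here, that single step, thian-4-yl to 1,1-dioxothian-4-yl on a saturated chain carbon bound to an amine nitrogen, is the only measured change.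

Compound 3 `c1ccc2c(c1)CN[C@@H](CN(CCCCNC1CCOCC1)[C@H]1CCCc3cccnc31)C2` has not been measured in this assay. It differs from compound 2 by oxan-4-yl in place of (1,1-dioxothian-4-yl)methyl on an amine nitrogen. The step from compound 1 to compound 2 bears on it only in part: it shows that the sulfone-bearing group gave a lower number than the plain sulfur ring, and compound 3 gives up that sulfone for an oxygen ring attached without the methylene. Among the measured compounds shown here, no measured pair covers removal of the linking carbon or the oxan-4-yl ring itself.

Given that the lower number of compound 2 rests on the dioxothian group, compound 3 is expected to return toward or past the number of compound 1, a step of a 3.2-fold higher number from compound 2 to compound 3 (0.51 log units; beyond the scatter) in the weaker direction, with wide uncertainty. The estimate for compound 3 in this assay is 55 nM, within 15 nM to 200 nM.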

Compound 3, half-maximal inhibitory concentration: 29.4 nM
Estimate against measurement, compound 3: 1.9-fold (0.27 log units) above; the range from low to high includes it.
By their numbers in this assay, from the lowest: compounds 2 and 3 (each within the scatter of the next); then compound 1.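

In this assay, the 1,1-dioxothian-4-yl group proves not to be needed for a number in this range at this amine nitrogen: oxan-4-yl in place of (1,1-dioxothian-4-yl)methyl gives a 1.7-fold higher number from compound 2 to compound 3 (0.24 log units; within the scatter), so compound 2 and compound 3 cannot be told apart on this read-out. The plain sulfur ring of compound 1 is now the outlier among the three, since replacing (thian-4-yl)methyl with oxan-4-yl gives a 2.4-fold lower number from compound 1 to compound 3 (0.37 log units; beyond the scatter), a modest step that changes the ring hetero atom and removes the linking carbon at once, so neither change can be credited with it alone. Nothing measured on hand accounts for either step.

Still open, as far as these compounds go, is which of those two changes carries the step from the sulfur ring: (oxan-4-yl)methyl and thian-4-yl on the same amine nitrogen would separate the ring atom from the linking carbon. Also open, from the compounds shown here alone, is whether any hetero atom in this ring matters at all, which a plain cyclohexyl group on that nitrogen would address.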